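The source may hold more compounds than are shown below. What is called first, only, known or untested is meant among the compounds shown, and "the series" means these compounds.

Measured so far:
compound 1 `O=C(Nc1ccc(N2CCOCC2=O)cc1)c1ccc2[nH]c(-c3ccc(Cl)s3)nc2c1`: < 10 ug/mL
compound 2 `O=C(CCc1ccc2[nH]c(-c3ccc(Cl)s3)nc2c1)Nc1ccc(N2CCOCC2=O)c(Cl)c1`: < 10 ug/mL

In a physicochemical assay for solubility, in phosphate buffer, at pH 7.0 (on this read-out lower numbers stand for lower solubility and higher numbers for higher solubility), compound 2 gives < 10 ug/mL, which is a limit of the assay and not a number. Compound 1 sits at the same kind of limit, as the limit of < 10 ug/mL in this assay, at which 2 of the 2 values shown sit, shows, so for this pair the two values reveal only that both lie under the reporting threshold. Compound 3 `Cc1cc(NC(=O)CCc2ccc3[nH]c(-c4ccc(Cl)s4)nc3c2)ccc1N1CCOCC1=O` differs from compound 2 by methyl in place of chloro on an aromatic carbon, in words methyl in place of chloro on an aromatic carbon. For the measured compounds named here, no measured step covers such a change here. The step that the limit leaves unreadable from compound 2 to compound 3 is expected to be small, with no direction beyond the scatter. Compound 3 is therefore estimated at 8 ug/mL, between 3 ug/mL and 20 ug/mL, most likely again reported as a limit.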

Compound 3, solubility: < 10 ug/mL
Compound 3: only a limit was reported; the forecaster's own chance of this, stated with the estimate: 70%; the middle value does not contradict the limit.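

In this assay compound 3 gives < 10 ug/mL as a limit of the assay and not a number, so no step from compound 2 to compound 3 can be read: the limit of < 10 ug/mL in this assay, at which 3 of the 3 values shown sit.

From the compounds shown here alone, whether methyl in place of chloro on an aromatic carbon changes this read-out at all remains open, as does any order among compound 1, compound 2 and compound 3.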